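Swapping the piperazine chain of compound 3 for a triazole diol

The compounds below may be only part of what the source reports. "The series", "measured", "known", "first", "only" and "open" are said of these compounds alone.

Of the compounds shown here, three sharing one core have been measured in a toxicity assay on L02 cells (Homo sapiens) for cytotoxicity, read by MTT assay, with a stated time of 72 h; on this read-out higher numbers stand for weaker inhibition and lower numbers for stronger inhibition. Compound 1 `CN1CCN(CCCCCn2c3c(c4ccccc42)C(=O)c2c[n+]([O-])c4ccccc4c2C3=O)CC1` gives 1640 nM, and compound 2 `O=C1c2c[n+]([O-])c3ccccc3c2C(=O)c2c1c1ccccc1n2CCCCN1CCNCC1` gives 1380 nM; the step of a 1.2-fold lower number from compound 1 to compound 2 (0.07 log units; within the scatter) is small. Compound 3 `CN1CCN(CCCCn2c3c(c4ccccc42)C(=O)c2c[n+]([O-])c4ccccc4c2C3=O)CC1` gives 80 nM, the lowest of the three numbers: the step of a 21-fold lower number from compound 1 to compound 3 (1.31 log units; beyond the scatter) and the step of a 17-fold lower number from compound 2 to compound 3 (1.24 log units; beyond the scatter) are both large, so compound 3 stands clearly apart as the strongest inhibitor here.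

Compound 4 `O=C1c2c[n+]([O-])c3ccccc3c2C(=O)c2c1c1ccccc1n2Cc1cn(C[C@H](O)CO)nn1` is not yet measured. It differs from compound 3 by 1-(2,3-dihydroxypropyl)-1H-1,2,3-triazol-4-yl in place of 3-(4-methylpiperazin-1-yl)propyl on a saturated chain carbon bound to an aromatic nitrogen. The whole side chain that both large steps touched is thus removed and replaced by a different group. Among the compounds with values here, no measured step covers this exchange directly; the two that bear on it, from compound 1 and from compound 2 to compound 3, show that altering this chain gave the two large steps already set out. With the chain gone entirely, a large rise in the number in this assay is expected, placing compound 4 at or beyond the level of compounds 1 and 2, so compound 4 is estimated at 3000 nM, within 800 nM to 15000 nM, an expected step of a 38-fold higher number from compound 3 to compound 4 (1.57 log units; beyond the scatter).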

Compound 4, half-maximal inhibitory concentration: 1130 nM
Compound 4: middle estimate off by 2.7-fold (0.42 log units), on the high side, within the range that was stated.
By their numbers in this assay, from the lowest: compound 3; then compounds 4, 2 and 1 (each within the scatter of the next).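

In this assay, putting 1-(2,3-dihydroxypropyl)-1H-1,2,3-triazol-4-yl on the saturated chain carbon bound to an aromatic nitrogen gives a 14-fold higher number from compound 3 to compound 4 (1.15 log units; beyond the scatter), so the low number of compound 3 does not survive the loss of its 3-(4-methylpiperazin-1-yl)propyl group. Measured against the other two chains, the exchange gives a 1.2-fold lower number from compound 2 to compound 4 (0.09 log units; within the scatter) and a 1.5-fold lower number from compound 1 to compound 4 (0.16 log units; within the scatter), which means that a side chain with no piperazine ring at all sits level with two that carry one, and that a piperazine ring alone does not set the number at this position, with compound 3 the only one of the four that stands apart. Nothing measured here explains why this one chain differs from the others.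

The compounds shown leave open whether the low number of compound 3 depends on the piperazine ring or would also appear with a simple dimethylamino group at the end of the same chain. They also leave open whether the triazole or the diol counts for more, a question that a triazole carrying a 4-methylpiperazin-1-yl group instead of the diol would address.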